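The source may report more compounds than this note shows. Statements on the series, on what has been measured and on what is new or still open speak of the compounds shown alone.

Compound 1 `O=C(O)CCc1ccc(OCc2ccccc2SC(F)(F)F)cc1` gives 74% in a functional assay on cells for agonist activity at Free fatty acid receptor 1 (Homo sapiens), read by FLIPR and calcium flux (a higher number here means a larger maximal response, a lower number a smaller maximal response), the lower of the two numbers at hand. Compound 3 `CC(CC(=O)O)c1ccc(OCc2ccccc2SC(F)(F)F)cc1` gives 109%, and for compound 2 `O=C(O)CC(O)c1ccc(OCc2ccccc2SC(F)(F)F)cc1` the result is "not determined" (no result reported). Within the data shown here, the one measured step, a number 35 percentage points higher from compound 1 to compound 3 (beyond the scatter), arises from methyl in place of hydrogen on a saturated chain carbon. Compound 4 `Cc1cc(OCc2ccccc2SC(F)(F)F)ccc1CCC(=O)O` differs from compound 1 by methyl in place of hydrogen on an aromatic carbon. Among the measured compounds shown here, no measured step shares this aromatic position, so the chain-carbon step offers only a loose guide, and a methyl on the ring is expected to move the response by a number 11 percentage points higher from compound 1 to compound 4 (beyond the scatter) at most modestly. Compound 4 is therefore estimated at 85%, within a range from 60% to 110%.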

Compound 4, largest response reached (reported as percent of maximum), in percent of the reference or control that the assay uses: 108%
Compound 4: the middle estimate sits 23 percentage points below what was measured; the measured number falls inside the stated range.
By their numbers in this assay, from the lowest: compound 1; then compounds 4 and 3 (each within the scatter of the next).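

In this assay, among these compounds, the methyl on the aromatic carbon ortho to a 2-carboxyethyl group gives a number 34 percentage points higher from compound 1 to compound 4 (beyond the scatter) and so shows that this ring position, untouched in the earlier compounds, responds strongly to a single added methyl. A rise beyond the scatter is thus no longer confined to the saturated chain carbon, where the methyl gave a number 35 percentage points higher from compound 1 to compound 3 (beyond the scatter) as well. Nothing at hand explains the rise. On these data alone, what an ethyl, a methoxy or a chlorine would give at this ring position stays open. So does the result of combining the ring methyl and the chain methyl in one compound.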